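This account rests on a few compounds, and the source may have more. Where it says the series, first, only, none or still open, it means among the compounds named here.

Measured in a functional assay on NCI-H727 cells (Homo sapiens) for cytotoxicity, with a stated time of 48 h; on this read-out lower numbers stand for stronger inhibition and higher numbers for weaker inhibition:
- compound 1 `COc1cc(O)c(C(=O)/C=C/c2ccc(F)cc2)c(OC)c1`: > 20000 nM
- compound 2 `COc1cc(OC)c(C(=O)/C=C/c2ccccc2SC)c(OC)c1`: 8700 nM
- compound 3 `COc1cc(O)c(C(=O)/C=C/c2ccccc2OC)c(OC)c1`: 11000 nM

Compound 1 shows > 20000 nM, which is a limit of the assay and not a number. That leaves two true numbers. Compound 2 gives 8700 nM and compound 3 gives 11000 nM, and these lie within the usual scatter of each other, so the two cannot be ranked.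

The next compound to be tested is compound 4 `COc1cc(OC)c(C(=O)/C=C/c2ccc(Cl)cc2)c(OC)c1`, which has 4-chlorophenyl in place of 2-(methylsulfanyl)phenyl on a double-bonded chain carbon bound to a double-bonded chain carbon.

Among the compounds with values here, no measured pair of compounds shows what a single change of this kind does, so any forecast is rough. Within the data shown here, compound 1 is the only measured compound carrying a halogen, and its > 20000 nM is a limit. On that slim basis, a modest move toward weaker inhibition is expected, with the estimated step of a 1.5-fold higher number from compound 2 to compound 4 (0.17 log units; within the scatter). Compound 4 is estimated at 13000 nM, within an expected range of 6000 nM to 25000 nM.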

Compound 4, half-maximal inhibitory concentration: 6000 nM
Estimate against measurement, compound 4: 2.2-fold (0.34 log units) above; measured number inside the range.
By their numbers in this assay, from the lowest: compounds 4, 2 and 3 (each within the scatter of the next). At a limit, above all of these: compound 1.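

In this assay, within the data shown here, this is the first change in a single place that can be read: putting 4-chlorophenyl in place of 2-(methylsulfanyl)phenyl on a double-bonded chain carbon bound to a double-bonded chain carbon gives a 1.5-fold lower number from compound 2 to compound 4 (0.16 log units; within the scatter). At this position, then, one of these substituted phenyl rings can replace the other with no difference that this assay can separate from ordinary scatter. Compound 1 remains a limit of the assay and not a number: the limit of > 20000 nM in this assay, at which 1 of the 4 values shown sits.

What the compounds shown leave open is how this position responds to a group of another kind, such as an amine, a carboxylic acid or a longer chain in place of the ring. Also open, going by these compounds, is what the chlorine and the methylsulfanyl group each contribute on their own, as both change in this one step.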